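Replacing a Tetrazole by a Carboxylic Acid on the Side Chain

The compounds below may be only part of what the source reports. "The series", "measured", "known", "first", "only" and "open" are said of these compounds alone.

Measured compounds:
- compound 1 `CC(CCc1cccc(OCc2ccc3ccccc3n2)c1)Cc1nnn[nH]1`: 17 nM
- compound 2 `CC(CCc1ccc(OCc2ccc3ccccc3n2)cc1)Cc1nnn[nH]1`: 25 nM
- compound 3 `O=C(O)CCC(Cc1ccc(OCc2ccc3ccccc3n2)cc1)c1ccccc1`: 31 nM

Three compounds share a core that carries a quinoline-methoxy aryl group and an acidic side chain, and all three were tested in an assay on membranes from lung (Cavia porcellus) for binding affinity to cysteinyl leukotriene receptor (Homo sapiens); a lower number here means a stronger inhibitor, a higher number a weaker inhibitor. Compound 1 gives the lowest of the three numbers, but its gaps to compound 2 and to compound 3 both lie within the scatter of repeated measurements, so the three are indistinguishable on these data.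

The new compound 4 `CC(CCC(=O)O)Cc1cccc(OCc2ccc3ccccc3n2)c1` is derived from compound 1 by one change: 3-carboxy-1-methylpropyl in place of 2-((1H-tetrazol-5-yl)methyl)propyl on a saturated chain carbon bound to an aromatic carbon. Compound 3 already shows that a carboxylic acid on a chain of this kind can sit on the same core and still give a number close to compound 1 and compound 2 in this assay. Among the measured compounds shown here, no directly comparable pair exists among the measured compounds, so the size of the step from compound 1 to compound 4 is open; a small loss, possibly just beyond the scatter, seems the most likely outcome.

Compound 4 is therefore expected to give 40 nM in this assay, within a range of 12 nM to 130 nM, which corresponds to an estimated step of a 2.4-fold higher number from compound 1 to compound 4 (0.37 log units; beyond the scatter).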

Compound 4, inhibition constant: 140 nM
Estimate against measurement, compound 4: 3.5-fold (0.54 log units) below; the measured number lies above the stated range.
By their numbers in this assay, from the lowest: compounds 1, 2 and 3 (each within the scatter of the next); then compound 4.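

In this assay, the side chain at this place, on a saturated chain carbon bound to an aromatic carbon, turns out to matter: 3-carboxy-1-methylpropyl in place of 2-((1H-tetrazol-5-yl)methyl)propyl gives an 8.2-fold higher number from compound 1 to compound 4 (0.92 log units; beyond the scatter). Among the compounds shown here, this is the first step that can be read, since the earlier compounds differed in more than one place and their numbers lay within the scatter of one another, so they could not show that this group affects the result. No measurement shown here explains the size of this step.

The step covers the whole exchange of one chain for the other, so the share of the five-membered aromatic ring and the share of the rest of the chain remain unseparated, and no other step between the compounds shown can be read, as compound 3, at 31 nM, differs from compound 4 in more than one place. On these data alone, it also remains open whether a shorter or longer chain ending in the carboxylic acid, or the same 3-carboxy-1-methylpropyl chain on the core of compound 2, would bring the number back towards that of compound 1.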